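The source may hold more compounds than are shown below. What is called first, only, known or untested is meant among the compounds shown, and "the series" means these compounds.

Measured set, in a functional assay on MCF7 cells (Homo sapiens) for cytotoxicity, read by CellTiter-Glo, with a stated time of 5 days; on this read-out higher numbers stand for weaker inhibition and lower numbers for stronger inhibition:
- compound 1, `CC/C(=C(/c1ccc(/C=C/C(=O)O)cc1)c1cc2cn[nH]c2cc1C)c1ccccc1`: 468 nM
- compound 2, `CC/C(=C(/c1ccc(/C=C/C(=O)O)cc1)c1cc(C)c2[nH]ncc2c1)c1ccccc1`: 59 nM
- compound 3, `CC/C(=C(/c1ccc(/C=C/C(=O)O)cc1)c1cc2cn[nH]c2cc1F)c1ccccc1`: 47 nM

Compound 3 gives the lowest number of the three in this assay. Its gap to compound 2 is small, a 1.3-fold lower number from compound 2 to compound 3 (0.10 log units; within the scatter), so the two cannot be ranked against each other; its gap to compound 1 is clear, a 10-fold lower number from compound 1 to compound 3 (1.00 log units; beyond the scatter). The other informative step, a 7.9-fold lower number from compound 1 to compound 2 (0.90 log units; beyond the scatter), moves the methyl around the fused system rather than exchanging it.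

Compound 4, `CC/C(=C(/c1ccc(/C=C/C(=O)O)cc1)c1cc2cn[nH]c2cc1Cl)c1ccccc1`, differs from compound 3 by chloro in place of fluoro on an aromatic carbon. Within the data shown here, only one measured step touches the same site: a 10-fold lower number from compound 1 to compound 3 (1.00 log units; beyond the scatter), which swapped methyl for fluoro on that aromatic carbon. Among the measured compounds shown here, no measured pair exchanges fluoro for chloro, so the size of the new step rests on that single comparison and on the general observation that the three measured compounds span a modest range. A halogen-for-halogen exchange is expected to move the number little, with the direction open.

Compound 4 is therefore expected to give about 55 nM in this assay, within 22 nM to 140 nM. The step this implies from compound 3 is expected to be a 1.2-fold higher number from compound 3 to compound 4 (0.07 log units; within the scatter), not clearly beyond the scatter.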

Compound 4, half-maximal inhibitory concentration: 137 nM
Compound 4: middle estimate off by 2.5-fold (0.40 log units), on the low side; the range from low to high includes it.
By their numbers in this assay, from the lowest: compounds 3 and 2 (each within the scatter of the next); then compound 4; then compound 1.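

In this assay, among these compounds, the halogen on this aromatic carbon, ortho to a large group, turns out not to be interchangeable: chloro in place of fluoro is a step beyond the scatter (a 2.9-fold higher number from compound 3 to compound 4 (0.46 log units; beyond the scatter)), and the earlier compounds held only one halogen at this place. Chloro still keeps a clear distance from methyl on the same carbon (a 3.4-fold lower number from compound 1 to compound 4 (0.53 log units; beyond the scatter)), which gives fluoro, chloro and methyl a graded order at this place among compounds 3, 4 and 1, while the step to compound 4 from the isomeric methyl compound is also beyond the scatter (a 2.3-fold higher number from compound 2 to compound 4 (0.37 log units; beyond the scatter)), unlike the gap between compound 2 and compound 3. Nothing in hand accounts for this order of the three groups.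

On these data alone, whether the order extends to other groups on this carbon, such as a methoxy, an amine or a nitrile, remains open, as does the place of plain hydrogen there relative to fluoro and methyl. Also open, as far as these compounds go, is whether the same order holds when the rest of the shared core changes, for instance with an amide in place of the carboxylic acid.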